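Three Limits and an Untested Anilide Amide

A few compounds are considered here, and "the series" means these few. Any claim that something is new, unique, unknown or untested is made for them only; others in the source may bear on it.

Measured in a functional assay on HL-60 cells (Homo sapiens) for antiproliferative activity, read by MTT assay, with a stated time of 24 h (a higher number here means a weaker inhibitor, a lower number a stronger inhibitor), each value a limit of the assay:
- compound 1 `CCCCNC(=O)COc1ccc(C(=O)c2c(CCCC)oc3ccccc23)cc1`: > 50000 nM
- compound 2 `CCCCc1oc2ccccc2c1C(=O)c1ccc(OCC(=O)N2CCCCC2)cc1`: > 50000 nM
- compound 3 `CCCCc1oc2ccccc2c1C(=O)c1ccc(OCC(=O)N2CCN(C(=O)OC(C)(C)C)CC2)cc1`: > 50000 nM

Compound 2 has no numerical value in this assay. Compound 2 gives > 50000 nM, which is a limit. The other two compounds offer no numerical reference either, as the record shows (the limit of > 50000 nM in this assay, at which 3 of the 3 values shown sit).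

The next compound to be measured is compound 4 `CCCCc1oc2ccccc2c1C(=O)c1ccc(OCC(=O)Nc2cccc(OC)c2)cc1`. It carries (3-methoxyphenyl)amino in place of piperidin-1-yl on a carbonyl carbon.

For the measured compounds named here, one measured step bears on this change, since it falls at the same carbonyl carbon: a step that the two limits leave unreadable from compound 1 to compound 2. Its size cannot be read, so it offers no size or direction to carry over. Compound 1 also has an amide hydrogen, and compound 1 gives > 50000 nM, again a limit. The aromatic ring entering in compound 4 has no measured precedent among these compounds, so a modest gain in potency remains possible, but a result at the limit is more likely.

The expected change is an at least 1.2-fold lower number from compound 2 to compound 4 (0.09 log units; that floor lies within the scatter), small if it can be read at all. Compound 4 is estimated at 40000 nM, with an expected range of 12000 nM to 80000 nM.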

Compound 4, half-maximal inhibitory concentration: > 50000 nM
Compound 4: no number, only a limit; the forecaster's own chance of this, stated with the estimate: 70%; at least 1.2-fold (0.09 log units) between middle value and limit.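

In this assay compound 4 gives > 50000 nM, which is a limit and not a number. No step from compound 1 or compound 2 to compound 4 can be read: the limit of > 50000 nM in this assay, at which 4 of the 4 values shown sit.

The compounds shown leave open whether any of these amide groups on the shared core gives a readable value, and how the groups rank against one another.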